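Swapping azepan-1-yl for 4-methylpiperazin-1-yl on a shared core

The source may report more compounds than this note shows. Statements on the series, on what has been measured and on what is new or still open speak of the compounds shown alone.

Of the compounds shown here, three sharing one core have been tested so far: compound 1 `CCCN(C)c1nc(Cc2c(F)cccc2F)c(C)c(=O)[nH]1`, compound 2 `Cc1c(Cc2c(F)cccc2F)nc(N(C)c2ccccc2)[nH]c1=O` and compound 3 `Cc1c(Cc2c(F)cccc2F)nc(N2CCCCCC2)[nH]c1=O`. In an ADME assay on MT4 cells (Homo sapiens) for cytotoxicity, read by MTT assay, with a stated time of 4 days (on this read-out lower numbers stand for higher toxicity in this test and higher numbers for lower toxicity in this test), compound 1 gives > 81000 nM, which is a limit and not a number. Compound 2 gives > 73000 nM, again a limit. Compound 3 gives > 75000 nM, also a limit, so it has no exact place among the others, whose values are limits as well.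

The next compound, compound 4 `Cc1c(Cc2c(F)cccc2F)nc(N2CCN(C)CC2)[nH]c1=O`, carries 4-methylpiperazin-1-yl in place of azepan-1-yl on an aromatic carbon. Within the data shown here, three measured steps bear on this change, since each alters the group at this same place. Among the measured compounds shown here, the first is a step that the two limits leave unreadable from compound 1 to compound 2. The second is a step that the two limits leave unreadable from compound 1 to compound 3. The third is a step that the two limits leave unreadable from compound 2 to compound 3. None of them has a readable size, and none of the three compounds yields a number in this assay. They offer no sign of a step in either direction, so no step beyond the scatter is expected. The estimated step is an at least 1.0-fold lower number from compound 3 to compound 4 (0.02 log units; that floor lies within the scatter). For compound 4 the estimate is 71000 nM, with an expected range from 35000 nM to 85000 nM, and a report as a limit alone is the likeliest outcome.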

Compound 4, half-maximal cytotoxic concentration: > 75000 nM
Compound 4: no number, only a limit; the forecaster's own chance of this, stated with the estimate: 80%; at least 1.0-fold (0.02 log units) between middle value and limit.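

In this assay compound 4 gives > 75000 nM, which is a limit and not a number. Its steps to compound 1, compound 2 and compound 3 therefore cannot be read. The compounds shown leave open whether 4-methylpiperazin-1-yl, azepan-1-yl, methyl(phenyl)amino and methyl(propyl)amino differ at all in this assay, since none of the four compounds has an exact value.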